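Halogen swap carried from one core to another

The source may report more compounds than this note shows. Statements on the series, on what has been measured and on what is new or still open speak of the compounds shown alone.

Compound 1 `COc1cccc(C2=CC(c3ccc(Cl)cc3)NC(=S)N2)c1` and compound 2 `COc1cccc(C2=CC(c3ccc(Br)cc3)NC(=S)N2)c1` share one core; compound 3 `COc1cc(C2=CC(c3ccc(Cl)cc3)NC(=S)N2)cc(OC)c1OC` rests on a second core, and the difference between the two cores is not broken down here. In a functional assay on HepG2 cells (Homo sapiens) for antiproliferative activity, read by sulforhodamine B assay, with a stated time of 48 h (a higher number here means a weaker inhibitor, a lower number a stronger inhibitor), compound 1 gives 54 nM and compound 2 gives 34 nM. Within the data shown here, the single change between them, (bromo in place of chloro on an aromatic carbon), made a 1.6-fold lower number from compound 1 to compound 2 (0.20 log units; within the scatter). In this assay compound 3 gives 11 nM, the lowest of the three numbers; its distance to compound 2 and to compound 1 is beyond the scatter in both cases, so among the measured compounds compound 3 is the most potent.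

Compound 4 `COc1cc(C2=CC(c3ccc(Br)cc3)NC(=S)N2)cc(OC)c1OC` awaits measurement. It stands to compound 3 as compound 2 stands to compound 1: the change is bromo in place of chloro on an aromatic carbon, and the description of the place agrees word for word with the earlier one, so this is the same change, now made on the core of compound 3. Among the measured compounds shown here, the only guide to its size is the earlier instance, which gave a 1.6-fold lower number from compound 1 to compound 2 (0.20 log units; within the scatter), a shift within the scatter. On that basis the step expected for compound 4 is a 1.4-fold lower number from compound 3 to compound 4 (0.14 log units; within the scatter), small and possibly not resolvable from repeat variation. Compound 4 is accordingly expected to give about 8 nM in this assay, with a likely range from 4 nM to 16 nM.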

Compound 4, half-maximal inhibitory concentration: 9.5 nM
Beside the measured number, compound 4's estimate is 1.2-fold (0.07 log units) below it; the range from low to high includes it.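

In this assay, the change from 4-chlorophenyl to 4-bromophenyl on the second core made a 1.2-fold lower number from compound 3 to compound 4 (0.06 log units; within the scatter), so on neither core does this swap move the number beyond repeat variation. Set side by side, the two instances do not differ: the same change on two cores in this assay, a 1.6-fold lower number (0.20 log units; within the scatter) from compound 1 to compound 2 and a 1.2-fold lower number (0.06 log units; within the scatter) from compound 3 to compound 4, 1.4-fold (0.14 log units) apart, within the scatter of two such steps This shows that the swap carried from the core of compound 1 to the core of compound 3 with no resolvable change in its size, but it does not rank bromo above chloro on either core, and with both steps this small it does not test whether the two cores would respond alike to a change with a larger effect, nor does it reach beyond these two cores.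

Going by these compounds, only chloro and bromo occupy this place on the aromatic ring, so it remains open whether a fluoro, a methoxy, a nitrile, an amine or a carboxylic acid there would give a step beyond the scatter, and whether such a step would carry from one core to the other. Also open, on these data alone, is which part of the difference between the two cores goes with the lower numbers on the core of compound 3, and whether a carbonyl in place of the thiocarbonyl would leave these numbers where they stand.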